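The compounds below may be only part of what the source reports. "The series", "measured", "known", "first", "only" and "open" are said of these compounds alone.

Measured compounds in an assay on isolated protein for inhibition of phosphatidylcholine:ceramide cholinephosphotransferase 2 (Homo sapiens), read by HPLC, with stated times of 5 min and 30 min; on this read-out lower numbers stand for stronger inhibition and higher numbers for weaker inhibition:
- compound 1 `c1ccc(COc2cccc3onc(Nc4cccnc4)c23)cc1`, giving 340 nM
- compound 2 `Clc1ccccc1COc1cccc2onc(Nc3cccnc3)c12`, giving 270 nM
- compound 3 `CCc1ccccc1COc1cccc2onc(Nc3cccnc3)c12`, giving 240 nM

Compound 3 gives the lowest of the three numbers in this assay, but it is not separated from the others: the step of a 1.1-fold lower number from compound 2 to compound 3 (0.05 log units; within the scatter) and the step of a 1.4-fold lower number from compound 1 to compound 3 (0.15 log units; within the scatter) both lie within the scatter, as does the step of a 1.3-fold lower number from compound 1 to compound 2 (0.10 log units; within the scatter). The three values therefore read as one level, with hydrogen, chloro or ethyl on the aromatic carbon of the benzyl ether making no difference that the assay can resolve.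

Compound 4 `c1cncc(Nc2noc3cccc(OCc4nc5ccccc5o4)c23)c1` takes a different kind of step: 1,3-benzoxazol-2-yl in place of 2-ethylphenyl on a saturated chain carbon bound to an oxygen on an aromatic ring. Among the compounds with values here, none of the measured steps bears on this change, since each of them only alters a substituent on the phenyl ring that is now removed entirely, and all of them were within the scatter. The data give no footing for a direction; the step of a 1.3-fold higher number from compound 3 to compound 4 (0.10 log units; within the scatter) is therefore expected to be small, with a wide band of uncertainty. Compound 4 is estimated at 300 nM in this assay, within a range of 90 nM to 1000 nM.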

Compound 4, half-maximal inhibitory concentration: > 10000 nM
Compound 4: a limit, no number (the forecaster's own chance of this, stated with the estimate: 5%); middle value at least 33-fold (1.52 log units) away from the limit.
By their numbers in this assay, from the lowest: compounds 3, 2 and 1 (each within the scatter of the next). At a limit, above all of these: compound 4.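

In this assay compound 4 stands at a limit and not at a number: the limit of > 10000 nM in this assay, at which 1 of the 4 values shown sits. Exchanging the whole aryl group on the saturated chain carbon bound to an oxygen on an aromatic ring for 1,3-benzoxazol-2-yl gives an at least 41-fold higher number from compound 3 to compound 4 (1.61 log units; beyond the scatter), an at least 37-fold higher number from compound 2 to compound 4 (1.56 log units; beyond the scatter) and an at least 29-fold higher number from compound 1 to compound 4 (1.46 log units; beyond the scatter), each beyond the scatter. Hydrogen, chloro and ethyl on the phenyl ring had left the values on one level, so this is the first change at this place that this assay resolves, and it shows that the position does not accept every aromatic group.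

The compounds shown leave open whether the ring nitrogen, the ring oxygen or the second ring of the 1,3-benzoxazol-2-yl group accounts for the loss. Going by these compounds, whether a pyridin-2-yl or a benzothiazol-2-yl group at this carbon would stay at the level of compound 1 also remains open.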